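Swapping chloro for methoxy on the ring of compound 3

This account rests on a few compounds, and the source may have more. Where it says the series, first, only, none or still open, it means among the compounds named here.

compound 1 `N=C(N)N/N=C(/C=C/c1ccc(F)cc1)c1ccccc1` gives 2500 nM
compound 2 `N=C(N)N/N=C(/C=C/c1ccc(Cl)cc1)c1ccccc1` gives 700 nM
compound 3 `N=C(N)N/N=C(/C=C/c1ccccc1Cl)c1ccccc1` gives 4200 nM

In a functional assay on MCF7 cells (Homo sapiens) for antiproliferative activity, read by MTT assay, with a stated time of 48 h (a higher number here means a weaker inhibitor, a lower number a stronger inhibitor), compound 3 stands at 4200 nM as the starting point. Only the second of the two steps that place it lies beyond the scatter: a 1.7-fold higher number from compound 1 to compound 3 (0.23 log units; within the scatter) and a 6.0-fold higher number from compound 2 to compound 3 (0.78 log units; beyond the scatter) are the measured gaps.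

Compound 4 `COc1ccccc1/C=C/C(=N/NC(=N)N)c1ccccc1` carries methoxy in place of chloro on an aromatic carbon, ortho to a large group (methoxy in place of chloro on an aromatic carbon).

Among the measured compounds shown here, no measured step makes this exchange. The closest in kind is a 3.6-fold lower number from compound 1 to compound 2 (0.55 log units; beyond the scatter) as a swap of one group for another on an aromatic carbon, and it is modest and sits at a different place. For the measured compounds named here, with only that guide, no step beyond the scatter is expected in this assay and no direction is favoured, though a modest step of either sign stays open. The estimated step is a 1.2-fold lower number from compound 3 to compound 4 (0.08 log units; within the scatter) and so stays small. The estimate for compound 4 is 3500 nM with an expected range from 1300 nM to 9000 nM overall.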

Compound 4, half-maximal inhibitory concentration: 7200 nM
For compound 4 the middle estimate is 2.1-fold (0.31 log units) below the measured one; measured number inside the range.
By their numbers in this assay, from the lowest: compound 2; then compounds 1, 3 and 4 (each within the scatter of the next, the first and the last beyond it).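

In this assay the step is a 1.7-fold higher number from compound 3 to compound 4 (0.23 log units; within the scatter), so at this place on the aromatic ring, ortho to a large group, methoxy in place of chloro leaves the number within the scatter. Among the compounds shown here, the earlier compounds carried only chloro or fluoro on this ring, and this pair adds a first reading for a group with an oxygen and a hydrogen-bond acceptor, with no change that can be told apart from the scatter. Nothing at hand gives a reason for the size of this step.

As far as these compounds go, whether methoxy in the ring place held by chloro in compound 2 would keep that lower number stays open. Also open, from the compounds shown here alone, is whether an amine or a carboxylic acid in the place of methoxy in compound 4 would stay within the scatter.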